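From vinyl to a methoxyphenyl ethenyl group

The compounds below may be only part of what the source reports. "The series", "measured", "known", "first", "only" and "open" are said of these compounds alone.

Values measured in a functional assay on HL-60 cells (Homo sapiens) for cytotoxicity, read by WST assay, with a stated time of 48 h (a higher number here means a weaker inhibitor, a lower number a stronger inhibitor), are these
Compound 1 `CCCCCC/C=C/C[C@H]1C[C@@H]([C@@H](O)c2ccccc2)CO[C@@H]1c1ccccc1` gives 4990 nM
Compound 2 `O[C@@H](c1ccccc1)[C@H]1CO[C@H](c2ccccc2)[C@@H](C/C=C/c2cccc(F)c2)C1` gives 9170 nM
Compound 3 `C=CC[C@H]1C[C@@H]([C@@H](O)c2ccccc2)CO[C@@H]1c1ccccc1` gives 36000 nM

In this assay compound 3 stands highest of the three, and so is the weakest inhibitor measured. Compound 4 `COc1ccc(/C=C/C[C@H]2C[C@@H]([C@@H](O)c3ccccc3)CO[C@@H]2c2ccccc2)cc1` has no value yet. The change from compound 3 is 2-(4-methoxyphenyl)ethenyl in place of vinyl on a saturated chain carbon bound to a saturated ring carbon and amounts to 2-(4-methoxyphenyl)ethenyl in place of vinyl on a saturated chain carbon bound to a saturated ring carbon.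

The closest measured step is a 3.9-fold higher number from compound 2 to compound 3 (0.59 log units; beyond the scatter) and it concerns vinyl and 2-(3-fluorophenyl)ethenyl at the same place. Also bearing on the change is a 7.2-fold higher number from compound 1 to compound 3 (0.86 log units; beyond the scatter) for a larger chain group giving way to vinyl. The step of a 1.8-fold higher number from compound 1 to compound 2 (0.26 log units; within the scatter) suggests that an aromatic ring and hexyl at the chain end serve alike here. Among the measured compounds shown here, no measured compound carries a methoxy group, so that part of the change remains untested.

A modest move to a lower number is therefore expected, and the estimated step is a 4.5-fold lower number from compound 3 to compound 4 (0.65 log units; beyond the scatter) in this case. Compound 4 is estimated at 8000 nM with an expected range from 3000 nM to 20000 nM in this assay once measured.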

Compound 4, half-maximal inhibitory concentration: 9010 nM
Compound 4: middle estimate off by 1.1-fold (0.05 log units), on the low side, within the range that was stated.
By their numbers in this assay, from the lowest: compounds 1, 4 and 2 (each within the scatter of the next); then compound 3.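

In this assay, the gain at this saturated chain carbon bound to a saturated ring carbon also holds for a group carrying oxygen, with a 4.0-fold lower number from compound 3 to compound 4 (0.60 log units; beyond the scatter) on going to 2-(4-methoxyphenyl)ethenyl. Swapping 3-fluorophenyl for 4-methoxyphenyl gives a 1.0-fold lower number from compound 2 to compound 4 (0.01 log units; within the scatter) and so no readable change, and swapping hexyl for 4-methoxyphenyl gives a 1.8-fold higher number from compound 1 to compound 4 (0.26 log units; within the scatter) and likewise no readable change. Among the compounds shown, the three larger chain ends therefore stand together, each beyond the scatter from vinyl in compound 3, and none goes against this.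

Nothing available explains why these three chain ends behave alike. From the compounds shown here alone, it remains open whether an amine, a carboxylic acid or a chain longer than hexyl at this chain end would stay with them.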